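The source may hold more compounds than are shown below. What is called first, only, known or untested is meant among the compounds shown, and "the series" means these compounds.

Compound 1, `CC(C)CCn1nc(-c2cccs2)c(O)c(C2=NS(=O)(=O)c3ccccc3N2)c1=O`, is the starting point. In an in vitro ADME assay on microsomes from liver (Homo sapiens) for metabolic stability, tested at 5 uM (on this read-out lower numbers stand for a shorter-lived compound and higher numbers for a longer-lived compound), compound 1 gives 0.2 h, which places it at the low end of the three numbers shown, with neither of the other two compounds separated from it by more than the scatter. Compound 2, `CC(C)CCn1nc(-c2cccs2)c(O)c(C2=NS(=O)(=O)c3cc(OC(C)C(N)=O)ccc3N2)c1=O`, carries a 1-carbamoylethoxy group on the aromatic ring and gives 0.217 h in this assay; the change gives a 1.1-fold higher number from compound 1 to compound 2 (0.04 log units; within the scatter). Compound 3, `CC(C)CCn1nc(-c2cccs2)c(O)c(C2=NS(=O)(=O)c3cc(OC(C)(C)C(N)=O)ccc3N2)c1=O`, carries a 1-carbamoyl-1-methylethoxy group instead and gives 0.35 h; here the change gives a 1.8-fold higher number from compound 1 to compound 3 (0.24 log units; within the scatter), and between the two side chains the step is a 1.6-fold higher number from compound 2 to compound 3 (0.21 log units; within the scatter).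

Compound 4, `CCC(Oc1ccc2c(c1)S(=O)(=O)N=C(c1c(O)c(-c3cccs3)nn(CCC(C)C)c1=O)N2)C(N)=O`, differs from compound 1 by 1-carbamoylpropoxy in place of hydrogen on an aromatic carbon. Both comparable changes, the steps from compound 1 to compound 2 and from compound 1 to compound 3, stayed within the scatter, so for compound 4 no step beyond the scatter is expected in this assay, and the expected step is a 1.4-fold higher number from compound 1 to compound 4 (0.15 log units; within the scatter). Compound 4 is therefore estimated at 0.28 h, with a range from 0.14 h to 0.56 h.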

Compound 4, half-life: 0.35 h
Beside the measured number, compound 4's estimate is 1.3-fold (0.10 log units) below it; low and high end bracket the measured number.
By their numbers in this assay, from the lowest: compounds 1, 2, 3 and 4 (each within the scatter of the next).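

In this assay, a third side chain on this aromatic carbon, 1-carbamoylpropoxy, again stays within the scatter of the unsubstituted compound, with a 1.8-fold higher number from compound 1 to compound 4 (0.24 log units; within the scatter) when it is added. Reshaping the side chain gives nothing readable either, with a 1.6-fold higher number from compound 2 to compound 4 (0.21 log units; within the scatter) for one added methyl and no change at the digits printed from compound 3 to compound 4 (within the scatter) for the swap between the two four-carbon groups, so the three side chains cannot be told apart on this read-out. Nothing available explains these numbers.

On these data alone, all three side chains end in the same carbamoyl group, so it stays open whether an amine or a carboxylic acid in its place would give a step beyond the scatter. A longer chain between the oxygen and that carbamoyl group is equally untested by these compounds.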